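From Compound 1 to Compound 3: An Added Phenyl

A few compounds are considered here, and "the series" means these few. Any claim that something is new, unique, unknown or untested is made for them only; others in the source may bear on it.

Among the measured compounds shown here, in an ADME assay on HEK-293T cells (Homo sapiens) for cytotoxicity, read by CCK-8 assay, with a stated time of 24 h (a lower number here means that less compound is tolerated, a higher number that more compound is tolerated), compound 1 `CN(Cc1ccccc1)C(=O)CSc1c[nH]c2c(Br)cccc12` gives 52500 nM, the only actual number so far. Compound 2 `CCOc1ccccc1CN(OC)C(=O)CSc1c[nH]c2cccc(Br)c12` returns only a limit, > 100000 nM. Compound 3 `O=C(CSc1c[nH]c2c(Br)cccc12)N(Cc1ccccc1)Cc1ccccc1` has not yet been measured, and it departs from compound 1 by phenyl in place of hydrogen on a saturated chain carbon bound to an amide-type nitrogen, with phenyl in place of hydrogen on a saturated chain carbon bound to an amide-type nitrogen. For the measured compounds named here, no measured step between closely matched compounds is available as a guide. The expected 1.2-fold lower number from compound 1 to compound 3 (0.07 log units; within the scatter) in this assay is small, with no direction beyond the scatter. For compound 3, the estimated value is 45000 nM, within an expected range from 18000 nM to 100000 nM.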

Compound 3, half-maximal cytotoxic concentration: > 100000 nM
Compound 3 was reported as a limit; the forecaster's own chance of this, stated with the estimate: 20%; middle value at least 2.2-fold (0.34 log units) from the limit.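

In this assay, phenyl in place of hydrogen on a saturated chain carbon bound to an amide-type nitrogen gives an at least 1.9-fold higher number from compound 1 to compound 3 (0.27 log units; that floor lies within the scatter). Among the compounds shown here, this is the only step read at this position, and it shows that the added phenyl brings no sign of a lower tolerated concentration, although its floor does not pass the scatter. Its full size cannot be read because compound 3 stands at a limit: the limit of > 100000 nM in this assay, at which 2 of the 3 values shown sit.

As far as these compounds go, the actual number for compound 3 stays open. So does whether a carboxylic acid or an amine in this place, instead of phenyl, would give a number that can be read.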